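The compounds below may be only part of what the source reports. "The series", "measured", "known", "first", "only" and "open" are said of these compounds alone.

Measured so far in a functional assay (aorta) with Rattus norvegicus as the target; a lower number here means a stronger inhibitor, a higher number a weaker inhibitor:
compound 1 `COC(=O)c1cc2ccccc2n1[C@@H]1c2cc(C#N)ccc2OC(C)(C)[C@H]1O`, 33000 nM
compound 2 `CCOC(=O)CN(c1ccccc1)C1c2cc(C#N)ccc2OC(C)(C)C1O`, a limit of the assay, > 30000 nM
compound 3 `CC1(C)Oc2ccc(C#N)cc2[C@H](Nc2ccccc2)[C@H]1O`, 1200 nM

Compound 3 holds the lowest of the two numbers in this assay; its nearest neighbour is compound 1, whose value sits well beyond the scatter above it. For compound 2 the assay reports only a limit, (the limit of > 30000 nM in this assay, at which 1 of the 3 values shown sits), and no number. Compound 2 carries an ester-bearing chain on the nitrogen that is bare in compound 3, and its limit stands far above the number for compound 3.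

Compound 4 `CCOC(=O)CCCN(c1ccccc1)[C@H]1c2cc(C#N)ccc2OC(C)(C)[C@@H]1O` is not yet measured. It differs from compound 3 by 3-(ethoxycarbonyl)propyl in place of hydrogen on a nitrogen on an aromatic ring. Given the limit for compound 2, a step towards a weaker inhibitor, beyond the scatter, is expected for compound 4, a 13-fold higher number from compound 3 to compound 4 (1.10 log units; beyond the scatter). Compound 4 is therefore estimated at 15000 nM, within 3000 nM to 60000 nM.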

Compound 4, half-maximal inhibitory concentration: > 30000 nM
Compound 4 ended at the assay's limit; the forecaster's own chance of this, stated with the estimate: 35%; middle value at least 2.0-fold (0.30 log units) from the limit.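

Within the data shown here, at the nitrogen on an aromatic ring, 3-(ethoxycarbonyl)propyl in place of hydrogen gives an at least 25-fold higher number from compound 3 to compound 4 (1.39 log units; beyond the scatter) in this assay, the first step readable across a single change. For compound 4 the result > 30000 nM is a limit of the assay and not a number, so the step has a lower bound but no full size. This chain on the nitrogen costs much of the activity of compound 3, and the result joins a second value at the limit: the limit of > 30000 nM in this assay, at which 2 of the 4 values shown sit.

Open, from the compounds shown here alone, is whether the ester or any substituent on this nitrogen drives the weakening. A methyl group there, or a carboxylic acid at the chain end, would separate the two.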